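Compound 4: amino in place of methyl on the chain

This account rests on a few compounds, and the source may have more. Where it says the series, first, only, none or still open, it means among the compounds named here.

Compound 2 `CCc1c(F)c(N)c2c(=O)cc(-c3ccc(N)c(F)c3)oc2c1F` gives 130 nM in a functional assay on MCF7 cells (Homo sapiens) for cytotoxicity, read by neutral red uptake, with a stated time of 3 days (on this read-out higher numbers stand for weaker inhibition and lower numbers for stronger inhibition), the highest of the three numbers in hand. Compound 1 `Cc1c(F)c(N)c2c(=O)cc(-c3ccc(N)c(F)c3)oc2c1F` gives 13 nM and compound 3 `CN(C)CC(=O)OCc1c(F)c(N)c2c(=O)cc(-c3ccc(N)c(F)c3)oc2c1F` gives 26 nM; the steps of a 10-fold higher number from compound 1 to compound 2 (1.00 log units; beyond the scatter) and a 5.0-fold lower number from compound 2 to compound 3 (0.70 log units; beyond the scatter) set compound 2 apart, whereas a 2.0-fold higher number from compound 1 to compound 3 (0.30 log units; within the scatter) stays within the scatter. Compound 4 `NCc1c(F)c(N)c2c(=O)cc(-c3ccc(N)c(F)c3)oc2c1F` differs from compound 2 by amino in place of methyl on a saturated chain carbon bound to an aromatic carbon. The step that bears most directly is a 5.0-fold lower number from compound 2 to compound 3 (0.70 log units; beyond the scatter), where a group with hydrogen-bond donor and acceptor likewise replaces the methyl on that chain carbon; a 2.0-fold higher number from compound 1 to compound 3 (0.30 log units; within the scatter) shows such a group on that carbon leaving the number near compound 1. Compound 4 is therefore expected to come in lower than compound 2, by roughly a 5.2-fold lower number from compound 2 to compound 4 (0.72 log units; beyond the scatter). Compound 4 is estimated at 25 nM, within a range of 8 nM to 80 nM.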

Compound 4, half-maximal inhibitory concentration: 26 nM
Compound 4: middle estimate off by 1.0-fold (0.02 log units), on the low side; the measured number falls inside the stated range.
By their numbers in this assay, from the lowest: compounds 1, 3 and 4 (each within the scatter of the next); then compound 2.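

On the saturated chain carbon bound to an aromatic carbon, amino in place of methyl gives a 5.0-fold lower number from compound 2 to compound 4 (0.70 log units; beyond the scatter) in this assay, so this single heavy atom change is enough to separate compound 4 from compound 2. The steps of no change at the digits printed from compound 3 to compound 4 (within the scatter) and a 2.0-fold higher number from compound 1 to compound 4 (0.30 log units; within the scatter) both stay within the scatter, which leaves only compound 2, with its ethyl, apart among the four compounds. No measurement at hand explains this difference. As far as these compounds go, whether a hydroxyl, a carboxylic acid or a longer chain ending in an amine on that carbon would stay with compound 1, compound 3 and compound 4 remains open.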